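Shortening an Allyloxy Chain: Expected Effect on Cytotoxicity

The source may report more compounds than this note shows. Statements on the series, on what has been measured and on what is new or still open speak of the compounds shown alone.

Compound 1, `CCOc1cc(/C=C2\SC(=S)N(c3cccc(F)c3)C2=O)ccc1O`, in an ADME assay on HeLa cells (Homo sapiens) for cytotoxicity, read by MTT assay, with a stated time of 3 days (on this read-out higher numbers stand for lower toxicity in this test and lower numbers for higher toxicity in this test), gives >= 100000 nM, a limit of the assay.
Compound 2, `C=CCOc1cc(/C=C2\SC(=S)N(c3ccc(F)cc3)C2=O)ccc1O`, in this assay gives 76400 nM.

In this assay, for the measured compounds named here, compound 2 holds the only plain number among the two measured compounds. The result for compound 1 is a limit of the assay, (the limit of >= 100000 nM in this assay, at which 1 of the 2 values shown sits). Going by the values given here, compound 1 and compound 2 differ in two places at once, so their pair yields no single step.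

Compound 3, `CCOc1cc(/C=C2\SC(=S)N(c3ccc(F)cc3)C2=O)ccc1O`, differs from compound 2 in one place only: methyl in place of vinyl on a saturated chain carbon bound to an oxygen on an aromatic ring. Among the compounds with values here, no measured pair shows this change on its own. Given that compound 2 already sits close to the limit of the assay, only a small shift is expected, in neither direction beyond the scatter. Compound 3 is accordingly estimated at 90000 nM, with a range from 40000 nM to 200000 nM. The step this estimate implies, a 1.2-fold higher number from compound 2 to compound 3 (0.07 log units; within the scatter), is expected to stay within the usual scatter, and a limit rather than a number is quite possible.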

Compound 3, half-maximal cytotoxic concentration: >= 100000 nM
Compound 3: only a limit was reported; the forecaster's own chance of this, stated with the estimate: 40%; at least 1.1-fold (0.04 log units) between middle value and limit.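

For the compounds shown here, the pair of compound 2 and compound 3 gives the only reading of the change from allyloxy to ethoxy, on a saturated chain carbon bound to an oxygen on an aromatic ring: an at least 1.3-fold higher number from compound 2 to compound 3 (0.11 log units; that floor lies within the scatter). As far as these compounds go, the result for compound 3 is a limit of the assay, so only a floor is known for this step, and the size of the change remains open. The step from 3-fluorophenyl to 4-fluorophenyl, which the earlier compounds could not isolate, now has a matched pair but cannot be read, because both results are limits: the limit of >= 100000 nM in this assay, at which 2 of the 3 values shown sit.

From the compounds shown here alone, whether a longer chain such as butoxy, or a carboxylic acid on the chain, would give a plain number in this assay stays open. So does the result of pairing 3-fluorophenyl with the allyloxy chain.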